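Swapping Halogens on a Hydrazone: Expected Cytotoxicity

A few compounds are considered here, and "the series" means these few. Any claim that something is new, unique, unknown or untested is made for them only; others in the source may bear on it.

Compound 1, `N/C(CC(O)c1ccc2ccccc2c1)=N\N=C\c1ccc(Cl)c(Cl)c1`: 100000 nM
Compound 2, `CCC/C(=N\N=C(/N)CC(O)c1cccc2ccccc12)c1ccccc1`: 29000 nM

In an ADME assay on L6 cells (Rattus norvegicus) for cytotoxicity, read by resazurin assay, with a stated time of 72 h (on this read-out higher numbers stand for weaker inhibition and lower numbers for stronger inhibition), compound 1 gives 100000 nM, the highest of the two numbers; compound 2 gives 29000 nM, a lower number, and the gap between them is beyond the scatter. Compound 3, `N/C(CC(O)c1ccc2ccccc2c1)=N\N=C\c1ccc(F)cc1`, has not yet been measured. It differs from compound 1 in one place: 4-fluorophenyl in place of 3,4-dichlorophenyl on a carbon with a double bond to nitrogen. Going by the values given here, no measured pair shows a change of this kind, so there is little to lean on. The expected step of no change at the digits printed from compound 1 to compound 3 (within the scatter) in this assay is none beyond the scatter. Compound 3 is therefore estimated at 100000 nM, with a likely range from 30000 nM to 300000 nM.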

Compound 3, half-maximal inhibitory concentration: > 298000 nM
Compound 3 gave a limit, no number; the forecaster's own chance of this, stated with the estimate: 40%; middle value at least 2.9-fold (0.47 log units) away from the limit.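

In this assay, compound 3 reads > 298000 nM, which is a limit and not a number. Putting 4-fluorophenyl in place of 3,4-dichlorophenyl gives an at least 2.9-fold higher number from compound 1 to compound 3 (0.47 log units; beyond the scatter), so the group at this place does bear on the read-out, moving it towards weaker inhibition of the cells. The full size of the step cannot be read: the limit of > 298000 nM in this assay, at which 1 of the 3 values shown sits.

The change swaps the halogen and alters how many the ring carries, so the two effects stay tangled. Going by these compounds, how a 4-chlorophenyl at this place would read remains open, and it would help separate them.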